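A few compounds are considered here, and "the series" means these few. Any claim that something is new, unique, unknown or untested is made for them only; others in the source may bear on it.

Measured in a functional assay on ZR-75-1 cells (Homo sapiens) for inhibition, read by sulforhodamine B assay; a higher number here means a weaker inhibitor of growth, a lower number a stronger inhibitor of growth:

Compound 1 `Cc1ccc2[nH]c(-c3ccc(-c4ccc(-c5cccc(Cl)c5)cc4)cc3)nc2c1` gives 3450 nM
Compound 2 `COc1cc(-c2ccc(-c3ccc(-c4nc5cc(C)ccc5[nH]4)cc3)cc2)cc(OC)c1OC` gives 190 nM
Compound 3 `FC(F)(F)c1ccc(-c2ccc(-c3ccc(-c4nc5ccccc5[nH]4)cc3)cc2)cc1` gives 48300 nM

Compound 3 has the highest number of the three, which makes it the weakest inhibitor of growth in this small set. Compound 1 lies lower and compound 2 lower still, both beyond the scatter of repeat measurements.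

The next compound, compound 4 `CN(C)c1ccc(-c2ccc(-c3ccc(-c4nc5ccccc5[nH]4)cc3)cc2)cc1`, differs from compound 3 in one place: dimethylamino in place of trifluoromethyl on an aromatic carbon, para to a large group (dimethylamino in place of trifluoromethyl on an aromatic carbon). Going by the values given here, no two measured compounds differ in just one place, so no measured step shows what a single swap of this kind does in this assay on its own.

The guide is therefore loose. Among the compounds with values here, compound 2 (at 190 nM) and compound 1 (at 3450 nM) differ from compound 3 in more than one place, so they show only that much lower numbers are possible among such structures. With compound 3 (at 48300 nM) at the top of the values seen so far, a move down seems more likely than a move up.

The expected change is a 24-fold lower number from compound 3 to compound 4 (1.38 log units; beyond the scatter) in size, towards a lower number and beyond the scatter. For compound 4 the estimated value is 2000 nM (range 200 nM to 20000 nM).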

Compound 4, concentration for 50% growth inhibition: 100000 nM
Compound 4: the middle estimate sits 50-fold (1.70 log units) below what was measured, and the stated range ends below it.
By their numbers in this assay, from the lowest: compound 2; then compound 1; then compound 3; then compound 4.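

In this assay, placing dimethylamino instead of trifluoromethyl on this aromatic carbon, para to a large group, gives a 2.1-fold higher number from compound 3 to compound 4 (0.32 log units; beyond the scatter) and so moves towards weaker inhibition of growth. Going by these compounds alone, this is the first single change that can be read on its own in this set, and it shows that a marked change of atoms at this position, with carbon and nitrogen entering where carbon and fluorine leave and a hydrogen-bond acceptor appearing where there was none, shifts the number only modestly and does not improve inhibition. Nothing measured here accounts for the direction or the small size of this step.

The compounds shown leave open what a carboxylic acid, a primary amine or a longer chain would do at the same position, and whether any of these would move the number down rather than up. They also leave open whether the same swap would give a step of similar size and direction on a core that carries a methyl group, as the cores of compound 1 and compound 2 do.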